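Benzylamino in place of pyrrolidin-1-yl: cytotoxicity notes

The source may hold more compounds than are shown below. What is called first, only, known or untested is meant among the compounds shown, and "the series" means these compounds.

The series is read in an ADME assay on SH-SY5Y cells (Homo sapiens) for cytotoxicity, read by MTT assay, with a stated time of 48 h; on this read-out higher numbers stand for weaker inhibition and lower numbers for stronger inhibition. Compound 1 (`COc1ccc(C(=O)/C=C/c2ccc(C(=O)O)cc2)c(O)c1`) gives > 100000 nM, which is a limit of the assay and not a number. Compound 2 (`COc1ccc(C(=O)/C=C/c2ccc(OCCCOc3ccccc3)c(OC)c2)c(O)c1`) gives > 100000 nM, again a limit. Compound 3 (`COc1ccc(C(=O)/C=C/c2ccc(C(=O)N3CCCC3)cc2)c(O)c1`) gives > 100000 nM, also a limit, so its position in the series has no number attached. Among the measured compounds shown here, the series so far rests on (the limit of > 100000 nM in this assay, at which 3 of the 3 values shown sit).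

The next change leads to compound 4 (`COc1ccc(C(=O)/C=C/c2ccc(C(=O)NCc3ccccc3)cc2)c(O)c1`), and it is benzylamino in place of pyrrolidin-1-yl on a carbonyl carbon. In words, benzylamino stands in place of pyrrolidin-1-yl on a carbonyl carbon, so a six-membered aromatic ring of carbon only replaces a five-membered non-aromatic ring.

For the measured compounds named here, the one measured step at this carbonyl carbon is a step that the two limits leave unreadable from compound 1 to compound 3. It gives no size to carry over, so no step beyond the scatter is expected in this assay. The expectation rests on compound 3, whose reading of > 100000 nM is a limit. The expected change is a number no higher from compound 3 to compound 4 (the limit leaves the size open), and a report as a limit again is the likeliest outcome. Compound 4 is estimated at 100000 nM, with an expected range from 40000 nM to 200000 nM.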

Compound 4, half-maximal inhibitory concentration: > 100000 nM
Compound 4: no number, only a limit; the forecaster's own chance of this, stated with the estimate: 80%; the middle value lies on the limit itself.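

In this assay compound 4 gives > 100000 nM, which is a limit of the assay and not a number. Among the compounds shown here, no step from compound 1 or compound 3 to compound 4 can be read, because the series rests on a single limit: the limit of > 100000 nM in this assay, at which 4 of the 4 values shown sit. The compounds shown leave open how any of these carbonyl-carbon replacements changes the half-maximal inhibitory concentration.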